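Removing one acetyl from a macrocyclic diacetate

The compounds below may be only part of what the source reports. "The series", "measured", "known", "first", "only" and "open" are said of these compounds alone.

Compound 1 `CCCC[C@H]1CCCC[C@H](C)[C@@H](O)c2cc(O)c(c(O)c2)[C@@H](CCCC)CCCC[C@H](C)[C@@H](O)c2cc(O)c1c(O)c2`: 5000 nM
Compound 2 `CCCC[C@H]1CCCC[C@H](C)[C@@H](OC(C)=O)c2cc(O)c(c(O)c2)[C@@H](CCCC)CCCC[C@H](C)[C@@H](OC(C)=O)c2cc(O)c1c(O)c2`: 11000 nM

Of the compounds shown here, two have been measured in an ADME assay on HaCaT cells (Homo sapiens) for cytotoxicity; on this read-out higher numbers stand for weaker inhibition and lower numbers for stronger inhibition. Compound 1 gives 5000 nM in this assay, and compound 2 gives 11000 nM, which is the higher of the two numbers; the gap between them lies beyond the usual scatter of repeated runs, so compound 2 shows the weaker inhibition of the pair. Compound 3 `CCCC[C@H]1CCCC[C@H](C)[C@@H](O)c2cc(O)c(c(O)c2)[C@@H](CCCC)CCCC[C@H](C)[C@@H](OC(C)=O)c2cc(O)c1c(O)c2` has not yet been measured. It is reached from compound 2 by a single change, (hydrogen in place of acetyl on an oxygen on a saturated carbon); cut one bond further out, this reads as acetoxy to hydroxy. Compound 3 thus carries one acetyl where compound 2 carries two and compound 1 carries none. On that basis the step from compound 2 to compound 3 in this assay is expected to be a 1.5-fold lower number from compound 2 to compound 3 (0.17 log units; within the scatter), a modest move toward stronger inhibition, roughly halfway to compound 1. The expected value for compound 3 is 7500 nM, within a range of 4000 nM to 14000 nM.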

Compound 3, half-maximal inhibitory concentration: 2900 nM
Estimate against measurement, compound 3: 2.6-fold (0.41 log units) above, and the stated range ends above it.
By their numbers in this assay, from the lowest: compounds 3 and 1 (each within the scatter of the next); then compound 2.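

In this assay the change from acetoxy to hydroxy at one position gives a 3.8-fold lower number from compound 2 to compound 3 (0.58 log units; beyond the scatter) and so lies beyond the scatter, showing that removing a single acetyl is enough to shift the read-out. The reverse kind of change, starting from the compound without acetyl, gives a 1.7-fold lower number from compound 1 to compound 3 (0.24 log units; within the scatter) and lies within the scatter, so one acetyl on an oxygen on a saturated carbon reads no differently from none, and only the second acetyl separates the compounds. No measurement is at hand that explains this difference between the first and the second acetyl.

The compounds shown leave open whether a methyl ether or a longer acyl group such as butyryl on this oxygen would behave as acetyl does. They also leave open whether a free amine at this carbon would follow the hydroxy compounds.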